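A few compounds are considered here, and "the series" means these few. Any claim that something is new, unique, unknown or untested is made for them only; others in the source may bear on it.

Of the compounds shown here, three that share one core have been tested so far in an ADME assay on HepG2 2.2.15 cells (Homo sapiens) for cytotoxicity, read by MTT assay, with a stated time of 8 days; a higher number here means that more compound is tolerated, a lower number that less compound is tolerated. Compound 1 `COCCNc1nc(F)c(-c2nn(Cc3ccc(C#N)cc3)c(=O)c3ccccc23)cc1Cl` gives > 100000 nM, which is a limit and not a number. Compound 2 `N#Cc1ccc(Cn2nc(-c3cc(Cl)c(NC[C@@H](O)CO)nc3F)c3ccccc3c2=O)cc1` gives > 100000 nM, again a limit. Compound 3 `COC(=O)CCNc1nc(F)c(-c2nn(Cc3ccc(C#N)cc3)c(=O)c3ccccc23)cc1Cl` gives > 100000 nM, also a limit. So the whole set sits at one reading: the limit of > 100000 nM in this assay, at which 3 of the 3 values shown sit.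

Compound 4 `N#Cc1ccc(Cn2nc(-c3cc(Cl)c(NCCC(=O)O)nc3F)c3ccccc3c2=O)cc1` comes from compound 3 through a single small change, (hydrogen in place of methyl on an oxygen next to a carbonyl group), with hydrogen in place of methyl on an oxygen next to a carbonyl group, so that methoxycarbonyl becomes carboxy.

Going by the values given here, two measured steps bear on this, a step that the two limits leave unreadable from compound 1 to compound 3 and a step that the two limits leave unreadable from compound 2 to compound 3. Each alters the same chain, and neither has a size that can be read. Among the compounds with values here, with no measured step showing any change, the expected result in this assay is a number no higher from compound 3 to compound 4 (the limit leaves the size open), meaning no shift beyond the usual scatter in either direction. A further limit is the most likely report. For compound 4 the estimated value is 100000 nM, with an expected range from 50000 nM to 200000 nM.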

Compound 4, half-maximal cytotoxic concentration: > 100000 nM
Compound 4 was reported as a limit; the forecaster's own chance of this, stated with the estimate: 85%; the middle value sits exactly at the limit.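

Compound 4 is also reported as a limit and not a number, so the steps joining compound 1, compound 2 and compound 3 to compound 4 cannot be read. All four compounds share one reading: the limit of > 100000 nM in this assay, at which 4 of the 4 values shown sit. The compounds shown leave open whether any change on this chain would lower the tolerated concentration.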